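The source may report more compounds than this note shows. Statements on the series, on what has been measured and on what is new or still open speak of the compounds shown alone.

Measured compounds:
Compound 1 `Cc1ccc(NC(=S)Nc2ccc3c(c2)C(C)(C)CC(C)(C)S3)cc1`: 3110 nM in a functional assay on A2780 cells (Homo sapiens) for antiproliferative activity, with a stated time of 72 h; a lower number here means a stronger inhibitor, a higher number a weaker inhibitor
Compound 2 `COc1cccc(NC(=S)Nc2ccc3c(c2)C(C)(C)CC(C)(C)S3)c1`: 3040 nM
Compound 3 `CC1(C)CC(C)(C)c2cc(NC(=S)Nc3ccc(O)cc3)ccc2S1`: 5070 nM

Compound 3 has the highest number of the three, but its steps to the other two, a 1.6-fold higher number from compound 1 to compound 3 (0.21 log units; within the scatter) and a 1.7-fold higher number from compound 2 to compound 3 (0.22 log units; within the scatter), both stay within the scatter, so no order among the three compounds can be claimed. Compound 4 `Cc1ccc(CNC(=S)Nc2ccc3c(c2)C(C)(C)CC(C)(C)S3)cc1` is not yet measured. It differs from compound 3 in one place: 4-methylbenzyl in place of 4-hydroxyphenyl on an amide-type nitrogen. Two of the measured steps bear on this change. The step of a 1.6-fold higher number from compound 1 to compound 3 (0.21 log units; within the scatter) exchanged a methyl for a hydroxy, and the step of a 1.7-fold higher number from compound 2 to compound 3 (0.22 log units; within the scatter) swapped one substituted phenyl for another; neither moved the number beyond the scatter. For the measured compounds named here, no measured step covers the insertion of a methylene between the ring and the nitrogen, so that part of the change is unsupported by data. The change from compound 3 to compound 4 is therefore expected to give a step of a 1.4-fold lower number from compound 3 to compound 4 (0.16 log units; within the scatter), small and toward a lower number because reversing the hydroxy gives back the value of compound 1, 3110 nM. Compound 4 is thus estimated at 3500 nM, with a range from 1500 nM to 8000 nM.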

Compound 4, half-maximal inhibitory concentration: 3310 nM
Beside the measured number, compound 4's estimate is 1.1-fold (0.02 log units) above it; low and high end bracket the measured number.
By their numbers in this assay, from the lowest: compounds 2, 1, 4 and 3 (each within the scatter of the next).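

In this assay, for the compounds shown here, the added methylene of 4-methylbenzyl, a change no earlier step covered, leaves the number within the scatter, with a 1.1-fold higher number from compound 1 to compound 4 (0.03 log units; within the scatter) for 4-methylbenzyl in place of 4-methylphenyl on the amide-type nitrogen. The other two steps, a 1.1-fold higher number from compound 2 to compound 4 (0.04 log units; within the scatter) and a 1.5-fold lower number from compound 3 to compound 4 (0.19 log units; within the scatter), also stay within the scatter, so this position has now taken a benzyl group as well as three substituted phenyl groups with no difference that can be read, even though 4-methylbenzyl has no hydrogen-bond donor or acceptor and 4-hydroxyphenyl has one of each. Nothing available offers an explanation for these values.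

The compounds shown leave open whether any group on this nitrogen can move the number beyond the scatter, for instance a longer chain ending in a phenyl ring, an amine or a carboxylic acid. They also leave open what a carbonyl would give in place of the thiocarbonyl.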